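This account rests on a few compounds, and the source may have more. Where it says the series, first, only, none or still open, it means among the compounds named here.

Measured so far:
- compound 1 `CCSc1ccc(-c2cncnc2-c2cc(OC)c(OC)c(OC)c2)cc1`: 370 nM
- compound 2 `CCOc1ccc(-c2cncnc2-c2cc(OC)c(OC)c(OC)c2)cc1`: 250 nM

Within the data shown here, in a functional assay on HeLa cells (Homo sapiens) for antiproliferative activity, read by CCK-8 assay, with a stated time of 72 h (on this read-out higher numbers stand for weaker inhibition and lower numbers for stronger inhibition), compound 2 gives 250 nM, and its only measured neighbour is compound 1. The step between them is a 1.5-fold lower number from compound 1 to compound 2 (0.17 log units; within the scatter), with ethoxy in place of ethylsulfanyl on an aromatic carbon, so the two cannot be ranked.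

Not yet measured is compound 3 `CCOc1ccc(-c2cncnc2-c2cc(OC)c(OC)c(OC)c2)cc1C(F)(F)F`, which keeps the ethoxy group of compound 2 and gains one substituent. The change is trifluoromethyl in place of hydrogen on an aromatic carbon.

Among the measured compounds shown here, the single measured step, a 1.5-fold lower number from compound 1 to compound 2 (0.17 log units; within the scatter), bears on this only loosely. For the measured compounds named here, it exchanges one group for another, whereas here a hydrogen gives way, and no measured pair shows a substituent entering at this place. The size of the new step therefore cannot be read from the data. A moderate rise in the number is assumed, as a judgement and not a finding, with compound 2 at 250 nM as the starting point.

The expected step is a 2.2-fold higher number from compound 2 to compound 3 (0.34 log units; beyond the scatter), an estimate with a wide margin.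

For compound 3 the estimated value is 550 nM, with an expected range from 130 nM to 2300 nM.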

Compound 3, half-maximal inhibitory concentration: 790 nM
The estimate for compound 3 lay 1.4-fold (0.16 log units) below the measured number; low and high end bracket the measured number.
By their numbers in this assay, from the lowest: compounds 2 and 1 (each within the scatter of the next); then compound 3.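

In this assay the step for trifluoromethyl in place of hydrogen is a 3.2-fold higher number from compound 2 to compound 3 (0.50 log units; beyond the scatter) and so, unlike the exchange of ethylsulfanyl for ethoxy, it can be read as a real change. This aromatic carbon, ortho to an ethoxy group and meta to a large group, is therefore not indifferent to substitution: here the hydrogen of compound 2 gives stronger inhibition than trifluoromethyl, although the step is modest and compound 3 at 790 nM keeps measurable antiproliferative activity. No supporting data bear on why the number rises.

From the compounds shown here alone, whether the rise belongs to trifluoromethyl itself or would follow any group entering at this carbon stays open, and a single fluorine, a methyl, a methoxy or an amine at the same place would help separate the two. Also open is whether the same step would appear with ethylsulfanyl in place of ethoxy, since the only trifluoromethyl pair shown carries the ethoxy group.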